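Fluorine on the benzyl ring of a hindered-phenol amide

The source may report more compounds than this note shows. Statements on the series, on what has been measured and on what is new or still open speak of the compounds shown alone.

Measured compounds:
- compound 1 `CC(C)(C)c1cc(C(=O)NCCC2CCN(Cc3ccccc3)CC2)cc(C(C)(C)C)c1O`: 109000 nM
- compound 2 `CC(C)(C)c1cc(/C=C/C(=O)NCC2CCN(Cc3ccccc3)CC2)cc(C(C)(C)C)c1O`: 48400 nM
- compound 3 `CC(C)(C)c1cc(/C=C/C(=O)NCCC2CCN(Cc3ccccc3)CC2)cc(C(C)(C)C)c1O`: 62300 nM

The three measured compounds were tested in an assay on isolated protein for inhibition of Amine oxidase [flavin-containing] A (Homo sapiens), read by fluorescence, with stated times of 15 min and 20 min; a higher number here means a weaker inhibitor, a lower number a stronger inhibitor. Compound 1 gives 109000 nM, compound 2 gives 48400 nM, and compound 3 gives 62300 nM. Compound 3 stands second highest of the three numbers; its nearest neighbour is compound 2, whose number is lower by an amount within the scatter, and the number of compound 1 is higher by an amount that also lies within the scatter. Within the data shown here, on these three values, then, the compounds cannot be told apart, and no single-point step between measured compounds exists to show how a small substituent change shifts the read-out.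

Compound 4 `CC(C)(C)c1cc(/C=C/C(=O)NCCC2CCN(Cc3ccc(F)cc3)CC2)cc(C(C)(C)C)c1O` differs from compound 3 in one place: fluoro in place of hydrogen on an aromatic carbon, on an aromatic carbon of a six-membered aromatic ring of carbon only, para to a large group. Among the measured compounds shown here, since no measured pair here shows the effect of such a change, the expectation rests on the closeness of the three measured numbers alone; a step from compound 3 to compound 4 of a 1.1-fold lower number from compound 3 to compound 4 (0.05 log units; within the scatter) is expected, that is, none beyond the scatter. The estimate for compound 4 in this assay is 55000 nM, with a range from 25000 nM to 120000 nM.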

Compound 4, half-maximal inhibitory concentration: 59600 nM
Beside the measured number, compound 4's estimate is 1.1-fold (0.03 log units) below it; low and high end bracket the measured number.
By their numbers in this assay, from the lowest: compounds 2, 4, 3 and 1 (each within the scatter of the next, the first and the last beyond it).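

In this assay, putting fluoro in place of hydrogen, which turns the benzyl group into a 4-fluorobenzyl group, gives a 1.0-fold lower number from compound 3 to compound 4 (0.02 log units; within the scatter) and so leaves the two compounds indistinguishable. Among these compounds, this is the first step that differs in one place only, and it shows that at this position, on an aromatic carbon para to a large group, this single fluorine atom produces no difference that can be told from the scatter of the assay, so compound 4 offers no gain or loss over compound 3 on this read-out. No other measurement is available here to bear on this result or to account for it.

Among the compounds shown here, the single step does not show whether a different group at this position, such as chloro, methoxy, trifluoromethyl, an amine or a carboxylic acid, would give a number beyond the scatter of compound 3. It also leaves open whether fluoro on another carbon of the same ring would behave alike, and whether the same change would read the same on compound 1 or compound 2, which carry a different chain on the shared core.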